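A few compounds are considered here, and "the series" means these few. Any claim that something is new, unique, unknown or untested is made for them only; others in the source may bear on it.

Measured so far:
Compound 1, `CC1(C)[C@H]2CC[C@]1(C)N(Cc1cn(-c3cccc(F)c3)nn1)C(=O)C2`, in a functional assay on A549 cells (Homo sapiens) for inhibition, read by MTT assay, with a stated time of 24 h (on this read-out lower numbers stand for stronger inhibition and higher numbers for weaker inhibition), gives 180 nM.
Compound 2, `CC1(C)[C@H]2CC[C@]1(C)N(Cc1cn(-c3cccc(C#N)c3)nn1)C(=O)C2`, gives 440 nM.
Compound 3, `CC1(C)[C@H]2CC[C@]1(C)N(Cc1cn(-c3cccc(Cl)c3)nn1)C(=O)C2`, gives 60 nM.

Compound 3 has the lowest number of the three, and both gaps to it lie beyond the scatter: a 3.0-fold lower number from compound 1 to compound 3 (0.48 log units; beyond the scatter) and a 7.3-fold lower number from compound 2 to compound 3 (0.87 log units; beyond the scatter). The next compound, compound 4, is `CC1(C)[C@H]2CC[C@]1(C)N(Cc1cn(-c3cccc(Br)c3)nn1)C(=O)C2`. It differs from compound 3 in one place only: bromo in place of chloro on an aromatic carbon.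

Among the compounds with values here, no bromo analogue has been measured, so the nearest guide is the earlier halogen swap on the same ring, a 3.0-fold lower number from compound 1 to compound 3 (0.48 log units; beyond the scatter), which brought a modest lowering. The other step, a 2.4-fold higher number from compound 1 to compound 2 (0.39 log units; beyond the scatter), went the opposite way but concerns cyano and does not bear directly on a halogen-to-halogen change. Going from chloro to bromo is a smaller change than fluoro to chloro, so the expected step in this assay is small, either within the scatter or a slight further lowering of the number, and is estimated as a 1.2-fold lower number from compound 3 to compound 4 (0.08 log units; within the scatter). Compound 4 is therefore expected to give about 50 nM in this assay, with a plausible range from 20 nM to 150 nM.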

Compound 4, half-maximal inhibitory concentration: 90 nM
For compound 4 the middle estimate is 1.8-fold (0.26 log units) below the measured one; the measured number falls inside the stated range.
By their numbers in this assay, from the lowest: compounds 3, 4 and 1 (each within the scatter of the next, the first and the last beyond it); then compound 2.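

Replacing chloro with bromo at this ring position in this assay gives a 1.5-fold higher number from compound 3 to compound 4 (0.18 log units; within the scatter) and so does not separate the two halogens, which means the drop seen from fluoro to chloro does not continue as a steady trend from chloro to bromo. Fluoro and bromo cannot be separated either, with a 2.0-fold lower number from compound 1 to compound 4 (0.30 log units; within the scatter) on the same read-out, even though fluoro and chloro can, while the step from cyano to bromo is clearer, with a 4.9-fold lower number from compound 2 to compound 4 (0.69 log units; beyond the scatter) and a gap that stands out from the scatter. No supporting evidence is available to explain why these groups fall as they do.

Going by these compounds, whether a methyl, methoxy or trifluoromethyl group, or a polar group such as an amine or a carboxylic acid, would match chloro and bromo at this position remains open, as does what would happen with a halogen placed elsewhere on the ring. Only one cell line and one read-out are shown, so it is also open whether these relationships would hold in other cells or reflect anything specific to this cell line.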